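Oxocyclohexyl to oxomorpholinyl on the fused aromatic ring

This account rests on a few compounds, and the source may have more. Where it says the series, first, only, none or still open, it means among the compounds named here.

Three members of the series carry a number in a physicochemical assay for lipophilicity, measured as octanol-water partition, at pH 7.4; a higher number here means a more lipophilic compound, a lower number a more polar compound. Compound 1 `CC(C)c1noc(N2CCC(Oc3cc(N4CCc5cc(C6CCCCC6=O)ccc54)ncn3)CC2)n1` gives 4.7 and stands second highest of the three. Compound 2 `CC(C)SC(=O)N1CCC(Oc2cc(N3CCc4ccccc43)ncn2)CC1` gives 5.3, the nearest value, a number 2.00 log units lower from compound 1 to compound 3 (beyond the scatter) is the furthest step, and compound 3 `CC(C)c1noc(N2CCC(Oc3cc(N4CCc5cc([S+]([O-])CCO)ccc54)ncn3)CC2)n1` gives 2.7.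

Compound 4 `CC(C)c1noc(N2CCC(Oc3cc(N4CCc5cc(N6CCOCC6=O)ccc54)ncn3)CC2)n1` has yet to be measured in this assay. It differs from compound 1 in one place: 3-oxomorpholin-4-yl in place of 2-oxocyclohexyl on an aromatic carbon. Among the compounds with values here, the one measured step that bears on this change is the replacement at the same aromatic carbon of the same leaving group, 2-oxocyclohexyl, by a group of 2 carbon, 2 oxygen and 1 sulfur with no ring, which gave a number 2.00 log units lower from compound 1 to compound 3 (beyond the scatter), a large drop beyond the scatter. In compound 4 the entering group keeps a six-membered non-aromatic ring and the same count of heavy atoms, but two of the carbons of the leaving ring give way to a nitrogen and an oxygen, so the step is expected to run in the same direction as the step from compound 1 to compound 3, yet to fall well short of it.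

On that basis the step of a number 1.30 log units lower from compound 1 to compound 4 (beyond the scatter) is expected to be beyond the scatter but moderate. Compound 4 is estimated at 3.4, within a range from 2.9 to 3.9.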

Compound 4, distribution coefficient: 3.1
The estimate for compound 4 lay 0.30 log units above the measured number; the measured number falls inside the stated range.
By their numbers in this assay, from the lowest: compound 3; then compound 4; then compound 1; then compound 2.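

In this assay, the number at this aromatic carbon moves far even when the ring size and the heavy-atom count of the group stay the same: with 3-oxomorpholin-4-yl in place of 2-oxocyclohexyl, the series shows a number 1.60 log units lower from compound 1 to compound 4 (beyond the scatter), a large step. The earlier step at this carbon changed the ring, the atom count and the atom types all at once, whereas this change keeps a six-membered non-aromatic ring with its carbonyl and alters only the ring atoms, so a large step at this position does not depend on losing the ring. The open-chain sulfur-bearing group still sits lower, with a number 0.40 log units higher from compound 3 to compound 4 (beyond the scatter), a modest step, and nothing shown accounts for either step.

From the compounds shown here alone, whether the step follows the ring nitrogen or the ring oxygen stays open, and a 2-oxopiperidin-1-yl group at the same aromatic carbon would separate the two. A morpholin-4-yl group there, without the carbonyl, would show how much of the step holds once that carbonyl is gone.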